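The source may hold more compounds than are shown below. What is called first, only, known or untested is meant among the compounds shown, and "the series" means these compounds.

Measured compounds in an assay on CHO-K1 cells for binding affinity to muscarinic acetylcholine receptor M5 (Homo sapiens); a lower number here means a stronger inhibitor, a higher number a weaker inhibitor:
- compound 1 `COc1ccc2c(c1)C(C(C)c1ccccn1)=C(CCN(C)C)C2` gives 8910 nM
- compound 2 `Cc1ccc2c(c1)CC(CCN(C)C)=C2C(C)c1ccccn1` gives 1450 nM

Of the two numbers, compound 2 carries the lower one. Its nearest neighbour is compound 1, whose value is higher by a margin that lies beyond the usual scatter of this assay. Among the compounds with values here, no pair of measured compounds differs in a single place, so no step size is established.

Compound 3 `CC(C1=C(CCN(C)C)Cc2cc(Cl)ccc21)c1ccccn1` remains to be measured. Compared with compound 2 it carries chloro in place of methyl on an aromatic carbon. There is no measured exchange of this kind to compare against, so the expectation rests on the single-atom nature of the swap. Taken as an expectation, the step of a 1.5-fold lower number from compound 2 to compound 3 (0.16 log units; within the scatter) is estimated to be small, at most a modest improvement, and may well fall within the scatter. For compound 3 the inhibition constant is estimated at 1000 nM, with a range from 400 nM to 3000 nM.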

Compound 3, inhibition constant: 724 nM
Estimate against measurement, compound 3: 1.4-fold (0.14 log units) above; the measured number falls inside the stated range.
By their numbers in this assay, from the lowest: compounds 3 and 2 (each within the scatter of the next); then compound 1.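

In this assay, within the data shown here, chloro in place of methyl on an aromatic carbon gives a 2.0-fold lower number from compound 2 to compound 3 (0.30 log units; within the scatter) as the only step that can be read in a single place. On this carbon the two groups therefore cannot be told apart, and compound 2 and compound 3 stand level within the scatter. The exchange of one heavy atom for another, neither of them a hydrogen-bond donor or acceptor, thus gives this position its first reading, and that reading is a flat one.

Among these compounds, still open is how a nitrile, a carboxylic acid or a primary amine would read on this same aromatic carbon, as methyl and chloro are the only two groups compared there. Also open, on these data alone, is whether the same exchange reads alike when the amine of the side chain carries a longer chain. Nothing at hand bears on why these two groups read alike.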